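A few compounds are considered here, and "the series" means these few. Any claim that something is new, unique, unknown or untested is made for them only; others in the source may bear on it.

Measured so far:
compound 1 `COC(=O)N[C@H](C(=O)N1CCC[C@H]1c1nc2ccc(C#CC#Cc3ccc4nc([C@@H]5CCCN5C(=O)[C@@H](NC(=O)OC)C(C)C)[nH]c4c3)cc2[nH]1)C(C)C`: 13000 nM
compound 2 `COC(=O)N[C@H](C(=O)N1C[C@H](C)C[C@H]1c1nc2cc(-c3ccc(-c4ccc5[nH]c([C@@H]6C[C@@H](C)CN6C(=O)[C@@H](NC(=O)OC)C(C)C)nc5c4)cc3)ccc2[nH]1)C(C)C`: 14000 nM

In an ADME assay on Huh-7 cells (Homo sapiens) for cytotoxicity, read by thymidine incorporation (a higher number here means that more compound is tolerated, a lower number that less compound is tolerated), compound 1 gives 13000 nM and compound 2 gives 14000 nM as its half-maximal cytotoxic concentration. Among the compounds with values here, these two numbers lie within the usual scatter of each other, so compound 2 stands level with the only other measured compound.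

Compound 3 `COC(=O)N[C@H](C(=O)N1C[C@@H](C)C[C@H]1c1nc2cc(-c3ccc(-c4ccc5[nH]c([C@@H]6C[C@H](C)CN6C(=O)[C@@H](NC(=O)OC)C(C)C)nc5c4)cc3)ccc2[nH]1)C(C)C` is a close relative of compound 2: the two compounds have the same atoms and bonds and differ only in configuration as drawn: 2 of 6 stereo elements differ; a stereocentre at a saturated ring carbon is drawn R in compound 2 and S in compound 3; a stereocentre at a saturated ring carbon is drawn R in compound 2 and S in compound 3. Each of the two stereocentres sits at a saturated ring carbon and is drawn R in compound 2 and S in compound 3.

Within the data shown here, no measured pair shows what such a change in configuration does in this assay and nothing here points to a direction. The nearest guide is compound 2 at 14000 nM and no shift beyond the scatter is expected. The expected change is no change at the digits printed from compound 2 to compound 3 (within the scatter) and no more than that. Compound 3 is estimated at 14000 nM with an expected range from 6000 nM to 30000 nM when it is measured.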

Compound 3, half-maximal cytotoxic concentration: > 20000 nM
Compound 3: no number, only a limit; the forecaster's own chance of this, stated with the estimate: 20%; middle value at least 1.4-fold (0.15 log units) away from the limit.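

In this assay compound 3 gives > 20000 nM, which is a limit of the assay and not a number. This is the first pair shown in which only the configuration changes, at two saturated ring carbons drawn R and then S, and it gives an at least 1.4-fold higher number from compound 2 to compound 3 (0.15 log units; that floor lies within the scatter). This inversion therefore shows no loss in the amount of compound tolerated, but the true size of the step stays hidden because the result reaches a limit: the limit of > 20000 nM in this assay, at which 1 of the 3 values shown sits.

From the compounds shown here alone, it remains open how far past its limit compound 3 lies, and whether inverting only one of the two stereocentres would have the same effect. The compounds shown also leave open what a fluorine or a hydroxyl group at these ring carbons would do in this assay.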